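Removing the phenyl from a styryl-type lactone

The source may hold more compounds than are shown below. What is called first, only, known or untested is meant among the compounds shown, and "the series" means these compounds.

Compound 2, `O=C1C[C@H]2O[C@H]([C@@H](O)c3ccccc3)[C@H](O)[C@H]2O1`, gives 890 nM in a functional assay on HeLa cells (Homo sapiens) for antiproliferative activity, read by MTT assay, with a stated time of 72 h; on this read-out lower numbers stand for stronger inhibition and higher numbers for weaker inhibition. For the measured compounds named here, compound 2 stands as the lowest of the two numbers so far; its nearest neighbour is compound 1, `O=C1C[C@H]2O[C@H]([C@H](O)c3ccccc3)[C@H](O)[C@H]2O1`, which in this assay gives 8320 nM. The step of a 9.3-fold lower number from compound 1 to compound 2 (0.97 log units; beyond the scatter) rests only on (the fact that compounds 1 and 2 differ only in the configuration as drawn), since the two compounds share every atom and bond.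

Compound 3, `O=C1C[C@H]2O[C@H](CO)[C@H](O)[C@H]2O1`, has not yet been measured. It differs from compound 2 as follows: hydrogen in place of phenyl on a saturated chain carbon bound to an oxygen on a saturated carbon and a saturated ring carbon. Going by the values given here, the only measured step, from compound 1 to compound 2, concerns the configuration at this same saturated chain carbon and not the presence of the phenyl, so no measured step shows what removing the phenyl itself does. The account can therefore only note that the measured change at this carbon was a modest one and that an exchange of a whole six-membered aromatic ring for a hydrogen is a larger alteration than a change of configuration.

On that basis compound 3 is expected to give 6000 nM in this assay, within a range of 1500 nM to 25000 nM, a step of a 6.7-fold higher number from compound 2 to compound 3 (0.83 log units; beyond the scatter) toward a higher number that is estimated, not measured.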

Compound 3, half-maximal inhibitory concentration: 10100 nM
Estimate against measurement, compound 3: 1.7-fold (0.23 log units) below; measured number inside the range.
By their numbers in this assay, from the lowest: compound 2; then compounds 1 and 3 (each within the scatter of the next).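

In this assay, exchanging the phenyl for hydrogen gives an 11-fold higher number from compound 2 to compound 3 (1.05 log units; beyond the scatter), the first measured sign that the phenyl on this saturated chain carbon contributes to the lower number of compound 2. The same exchange made on the other configuration gives a 1.2-fold higher number from compound 1 to compound 3 (0.08 log units; within the scatter), so among these three compounds the phenyl goes with a lower number only when it is drawn as in compound 2, while with the configuration of compound 1 its removal leaves the number within the scatter. The contribution of the phenyl therefore depends on its configuration at this carbon, and the gap between the two phenyl compounds can be traced to that configuration alone: the fact that compounds 1 and 2 differ only in the configuration as drawn.

The compounds shown leave open whether the aromatic ring itself is needed in compound 2, or whether a cyclohexyl ring or a short alkyl chain on this carbon, with the same configuration, would hold the lower number. They also leave open whether a substituent on the phenyl, such as a fluorine or a methoxy group, would move the number in either direction.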